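A few compounds are considered here, and "the series" means these few. Any claim that something is new, unique, unknown or untested is made for them only; others in the source may bear on it.

Of the compounds shown here, three built on one shared core have been tested in a functional assay on MGC-803 cells (Homo sapiens) for inhibition, read by MTT assay, with a stated time of 72 h; on this read-out higher numbers stand for weaker inhibition and lower numbers for stronger inhibition. Compound 1 `Cc1cc(Nc2ccn(Cc3cccc4ccccc34)n2)n2nc(SCc3ccc(Br)cc3)nc2n1` gives 3240 nM, compound 2 `Cc1ccc(CSc2nc3nc(C)cc(Nc4cc(-c5ccccc5)[nH]n4)n3n2)cc1` gives 6960 nM, and compound 3 `Cc1cc(Nc2ccn(Cc3ccc(C(F)(F)F)cc3)n2)n2nc(SCc3ccc(Br)cc3)nc2n1` gives 2590 nM, the lowest of the three numbers, though compound 1 sits within the scatter of it and only compound 2 lies beyond. Compound 4 `COc1ccc(Cn2ccc(Nc3cc(C)nc4nc(SCc5ccc(Br)cc5)nn34)n2)cc1` differs from compound 3 by methoxy in place of trifluoromethyl on an aromatic carbon. Within the data shown here, the one measured step that also exchanges the group on the saturated chain carbon bound to an aromatic nitrogen, a 1.3-fold lower number from compound 1 to compound 3 (0.10 log units; within the scatter), stayed within the scatter, so no change beyond the scatter is expected here. The step from compound 3 to compound 4 is expected to be a 1.1-fold higher number from compound 3 to compound 4 (0.03 log units; within the scatter). In this assay compound 4 is estimated at 2800 nM, within a range from 1200 nM to 6500 nM.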

Compound 4, half-maximal inhibitory concentration: 12600 nM
The estimate for compound 4 lay 4.5-fold (0.65 log units) below the measured number; measured number outside the range, above it.
By their numbers in this assay, from the lowest: compounds 3 and 1 (each within the scatter of the next); then compounds 2 and 4 (each within the scatter of the next).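

In this assay, the earlier exchange on this benzyl group, a 1.3-fold lower number from compound 1 to compound 3 (0.10 log units; within the scatter), suggested that the position was tolerant. The para group on that ring does matter, however: methoxy in place of trifluoromethyl gives a 4.9-fold higher number from compound 3 to compound 4 (0.69 log units; beyond the scatter), beyond the scatter, and replacing naphthalen-1-yl with 4-methoxyphenyl gives a 3.9-fold higher number from compound 1 to compound 4 (0.59 log units; beyond the scatter), also beyond it. Nothing available explains this loss of inhibition. Still open, as far as these compounds go, is how an amine or a carboxylic acid on that same aromatic carbon would read, and whether a longer alkoxy chain would follow methoxy.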